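The source may hold more compounds than are shown below. What is called first, only, known or untested is meant among the compounds shown, and "the series" means these compounds.

In an ADME assay on L02 cells (Homo sapiens) for inhibition, read by CCK-8 assay, with a stated time of 48 h (on this read-out higher numbers stand for weaker inhibition of growth and lower numbers for stronger inhibition of growth), compound 1 (`CCc1ccc(Nc2nc(Nc3ccc(N4CCN(C)CC4)cn3)ncc2Cl)cc1`) gives 12100 nM and compound 2 (`CC(C)c1ccc(Nc2nc(Nc3ccc(N4CCN(C)CC4)cn3)ncc2Cl)cc1`) gives 13700 nM on the same core. The change between these two is small (a 1.1-fold higher number from compound 1 to compound 2 (0.05 log units; within the scatter)) and stays within the scatter. Compound 3 (`Cc1cc(C)c(Nc2nc(Nc3ccc(N4CCN(C)CC4)cn3)ncc2Cl)c(C)c1`) gives 20500 nM and so stands within the scatter of both other compounds.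

The next compound is compound 4 (`COc1cccc(Nc2nc(Nc3ccc(N4CCN(C)CC4)cn3)ncc2Cl)c1`). Its difference from compound 3 is as follows: 3-methoxyphenyl in place of 2,4,6-trimethylphenyl on a nitrogen on an aromatic ring.

The closest precedents are the two replacements of one aryl group by another on that same nitrogen (a 1.7-fold higher number from compound 1 to compound 3 (0.23 log units; within the scatter) and a 1.5-fold higher number from compound 2 to compound 3 (0.18 log units; within the scatter)), and both stay within the scatter. For the measured compounds named here, no measured compound carries a methoxy group, so this precedent is indirect. A step beyond the scatter is therefore not expected in this assay, and the estimated step is small (a 1.5-fold lower number from compound 3 to compound 4 (0.17 log units; within the scatter)). For compound 4 the expected value is 14000 nM with an estimated range from 6000 nM to 30000 nM in this read-out.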

Compound 4, concentration for 50% growth inhibition: 3470 nM
The estimate for compound 4 lay 4.0-fold (0.61 log units) above the measured number; measured number outside the range, below it.
By their numbers in this assay, from the lowest: compound 4; then compounds 1, 2 and 3 (each within the scatter of the next).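

In this assay, this nitrogen on the shared core proves sensitive to the choice of aryl group, with 3-methoxyphenyl giving stronger inhibition of growth than each earlier group (a 5.9-fold lower number from compound 3 to compound 4 (0.77 log units; beyond the scatter); a 3.9-fold lower number from compound 2 to compound 4 (0.60 log units; beyond the scatter); a 3.5-fold lower number from compound 1 to compound 4 (0.54 log units; beyond the scatter)). Exchanges among 4-ethylphenyl, 4-isopropylphenyl and 2,4,6-trimethylphenyl had all stayed within the scatter, so the series now shows a change at this place that goes beyond it, although compound 4 is the only example. Nothing available explains the shift in the read-out.

Compound 4 differs from the others in both the group it carries and where that group sits on the ring, and the two cannot be separated here. From the compounds shown here alone, whether the shift follows the oxygen or the chain on it remains open, and 3-hydroxyphenyl, 3-ethoxyphenyl or 4-methoxyphenyl on the same nitrogen would bear on this.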